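The source may report more compounds than this note shows. Statements on the series, on what has been measured and on what is new or still open speak of the compounds shown alone.

Working notes on the series

The three measured compounds share one core and differ only in the group on the carbonyl carbon whose other neighbour is the amide-type nitrogen. In an assay on THP-1 cells for displacement of a labelled ligand from C-C chemokine receptor type 1 (Homo sapiens) (on this read-out higher numbers stand for weaker inhibition and lower numbers for stronger inhibition), compound 1 `CC(C)C(=O)NC(C(=O)N1CCC(c2ccc(Cl)cc2)CC1)C(C)C` gives 388 nM. Compound 3 `CC(C)C(NC(=O)Oc1ccccc1)C(=O)N1CCC(c2ccc(Cl)cc2)CC1` gives 265 nM; the one-place change of phenoxy in place of isopropyl on a carbonyl carbon produced a 1.5-fold lower number from compound 1 to compound 3 (0.17 log units; within the scatter). Compound 2 `Cc1ccc(C(=O)N[C@@H](C(=O)N2CCC(c3ccc(Cl)cc3)CC2)C(C)C)cc1` gives 25 nM and stands lowest of the three numbers, separated from compound 3 and from compound 1 by gaps beyond the scatter.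

Compound 4 `CC(C)[C@@H](NC(=O)Nc1ccccc1)C(=O)N1CCC(c2ccc(Cl)cc2)CC1` is not yet measured. The change from compound 2 is anilino in place of 4-methylphenyl on a carbonyl carbon.

Within the data shown here, only the step from compound 1 to compound 3 is a single change at this carbonyl carbon, and it stayed within the scatter; it does not cover an anilino group. Compound 2 and compound 3 also differ at this carbonyl carbon, and their values lie far apart, so a change at this place can move this assay considerably. Compound 4, like compound 3, links the carbonyl carbon to the phenyl ring through one further atom, so a number nearer compound 3 than compound 2 is expected, an estimated 6.0-fold higher number from compound 2 to compound 4 (0.78 log units; beyond the scatter). For compound 4 the estimate is 150 nM, expected within 50 nM to 500 nM.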

Compound 4, half-maximal inhibitory concentration: 616 nM
For compound 4 the middle estimate is 4.1-fold (0.61 log units) below the measured one; the measured number lies above the stated range.
By their numbers in this assay, from the lowest: compound 2; then compounds 3, 1 and 4 (each within the scatter of the next, the first and the last beyond it).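

Anilino in place of 4-methylphenyl on a carbonyl carbon gives a 25-fold higher number from compound 2 to compound 4 (1.39 log units; beyond the scatter) in this assay and is read as large, whereas the one earlier single change at this place stayed within the scatter. This direct step shows that this assay can respond strongly at this carbonyl carbon even when the leaving and entering groups have equal heavy-atom counts and the same kind of aromatic ring, the counted differences being the anilino nitrogen and its hydrogen-bond donor. No supporting measurement bears on why the number rises so far, and the step itself gives no explanation.

The change removes the methyl group and also places a nitrogen on the carbonyl carbon, so the compounds shown do not separate the share of each in this step. A plain phenyl group or a benzyl group on this carbonyl carbon, or a 4-methylanilino group in the same place, would be needed to divide the step between these two parts of the change.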